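This account rests on a few compounds, and the source may have more. Where it says the series, first, only, none or still open, it means among the compounds named here.

Of the compounds shown here, two have been measured so far. Compound 1 `O=C(/C=C/c1cccc(F)c1)Nc1ccc2c(c1)COC2=O` gives 34 nM in a functional assay on cells (T-cell, Mus musculus) for inhibition (on this read-out higher numbers stand for weaker inhibition and lower numbers for stronger inhibition), and compound 2 `Cc1ccccc1NC(=O)Nc1ccc2c(c1)COC2=O` gives 900 nM in this assay, the higher of the two numbers; the gap between compound 2 and compound 1 lies beyond the usual scatter. Compound 3 `CCCNC(=O)Nc1ccc2c(c1)COC2=O` has not been measured. It differs from compound 2 in one place: propyl in place of 2-methylphenyl on an amide-type nitrogen. Within the data shown here, no measured pair mirrors this change, so the expected step of a 2.2-fold higher number from compound 2 to compound 3 (0.35 log units; beyond the scatter) is a modest weakening, though none beyond the scatter remains possible. Compound 3 is estimated at 2000 nM, within a range of 500 nM to 10000 nM.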

Compound 3, half-maximal inhibitory concentration: 58100 nM
The estimate for compound 3 lay 29-fold (1.46 log units) below the measured number, outside the stated range (above it).
By their numbers in this assay, from the lowest: compound 1; then compound 2; then compound 3.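

In this assay, among these compounds, the group on this amide-type nitrogen matters far more than the earlier compounds could show: propyl in place of 2-methylphenyl gives a 65-fold higher number from compound 2 to compound 3 (1.81 log units; beyond the scatter) in a single change. Among the compounds shown here, this is the first one-place comparison, and it shows a large loss of inhibition on going from the aromatic ring to the open chain. No measurement shown accounts for the size of this step.

On these data alone, whether the ring itself or the size of the group counts stays open. Phenyl, benzyl or a longer chain such as hexyl on this nitrogen would separate these readings.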